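Bromo in Place of Ethyl: What Cytotoxicity to Expect

The source may report more compounds than this note shows. Statements on the series, on what has been measured and on what is new or still open speak of the compounds shown alone.

Compound 2 `CCc1ccc(NC(=S)OCCc2ccccn2)cc1` was tested in an ADME assay on MT4 cells (Homo sapiens) for cytotoxicity, read by MTT assay (on this read-out lower numbers stand for higher toxicity in this test and higher numbers for lower toxicity in this test), and gave 44000 nM. Compound 1 `S=C(Nc1cccc(Cl)c1)OCCc1ccccn1` gave 47000 nM in this assay, so the two numbers sit within the usual scatter of each other and neither stands apart. Compound 3 `S=C(Nc1ccc(Br)cc1)OCCc1ccccn1` has not been measured yet. It differs from compound 2 by bromo in place of ethyl on an aromatic carbon. Going by the values given here, with only two measured compounds, both close together, no step beyond the scatter is expected, and the estimated step of a 1.0-fold higher number from compound 2 to compound 3 (0.01 log units; within the scatter) is accordingly small. Compound 3 is expected to give about 45000 nM in this assay, within a range from 20000 nM to 100000 nM.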

Compound 3, half-maximal cytotoxic concentration: 37000 nM
Compound 3: the middle estimate sits 1.2-fold (0.09 log units) above what was measured; the measured number falls inside the stated range.
By their numbers in this assay, from the lowest: compounds 3, 2 and 1 (each within the scatter of the next).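

Putting bromo (1 heavy atom) in place of ethyl (2 heavy atoms) on the aromatic carbon leaves the number in this assay within the scatter (a 1.2-fold lower number from compound 2 to compound 3 (0.08 log units; within the scatter)). This is the first direct single-place comparison among these compounds, and it shows that this particular swap brings no clear shift in cytotoxicity in this test. Nothing available bears on why the two groups read alike.

On these data alone, whether an amine, a carboxylic acid or a longer chain at this same place would move the number beyond the scatter remains open.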